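Thiourea aryl swap: predicting a pyridin-3-yl analogue

This account rests on a few compounds, and the source may have more. Where it says the series, first, only, none or still open, it means among the compounds named here.

Compound 1, `Cc1ccccc1NC(=S)N1CCc2c(sc(NC(=O)c3ccccc3Cl)c2C(N)=O)C1`, gives 11700 nM in a functional assay on MKN-74 cells (Homo sapiens) for antiproliferative activity, with a stated time of 24 h; on this read-out higher numbers stand for weaker inhibition and lower numbers for stronger inhibition.
Compound 2, `COc1ccccc1NC(=S)N1CCc2c(sc(NC(=O)c3ccccc3Cl)c2C(N)=O)C1`, gives 35200 nM in this assay.
Compound 3, `NC(=O)c1c(NC(=O)c2ccccc2Cl)sc2c1CCN(C(=S)Nc1c(Cl)cccc1Cl)C2`, gives 4020 nM in this assay.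

Compound 3 holds the lowest number of the three: a 2.9-fold lower number from compound 1 to compound 3 (0.46 log units; beyond the scatter) and an 8.8-fold lower number from compound 2 to compound 3 (0.94 log units; beyond the scatter), while a 3.0-fold higher number from compound 1 to compound 2 (0.48 log units; beyond the scatter). Compound 4, `NC(=O)c1c(NC(=O)c2ccccc2Cl)sc2c1CCN(C(=S)Nc1cccnc1)C2`, carries pyridin-3-yl in place of 2,6-dichlorophenyl on an amide-type nitrogen. Within the data shown here, no measured step swaps the aryl for a heteroaryl, so the bearing is indirect; the two steps into compound 3 show that the 2,6-dichlorophenyl sits at the favourable end, and leaving it is expected to raise the number in this assay modestly, a 3.7-fold higher number from compound 3 to compound 4 (0.57 log units; beyond the scatter). Compound 4 is therefore estimated at 15000 nM, within 4500 nM to 50000 nM.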

Compound 4, half-maximal inhibitory concentration: 38600 nM
Compound 4: the middle estimate sits 2.6-fold (0.41 log units) below what was measured, and the stated range covers the measured number.
By their numbers in this assay, from the lowest: compound 3; then compound 1; then compounds 2 and 4 (each within the scatter of the next).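

Moving from the 2,6-dichlorophenyl to pyridin-3-yl on this amide-type nitrogen gives up the low number of the series, with a 9.6-fold higher number from compound 3 to compound 4 (0.98 log units; beyond the scatter) in this assay. The heteroaryl ring also separates from the 2-methylphenyl, with a 3.3-fold higher number from compound 1 to compound 4 (0.52 log units; beyond the scatter), but not from the 2-methoxyphenyl, with a 1.1-fold higher number from compound 2 to compound 4 (0.04 log units; within the scatter), so a ring with a hetero atom offers no advantage over these aryl groups here. No supporting measurement bears on this result. The compounds shown leave open how a plain phenyl would read, and therefore whether the ring nitrogen or the departing chlorine atoms account for the step.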